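Working notes: compound 3 to compound 4, cytotoxicity

The compounds below may be only part of what the source reports. "The series", "measured", "known", "first", "only" and "open" are said of these compounds alone.

Measured in (an ADME assay on BHK-21 cells (Mesocricetus auratus) for cytotoxicity, read by MTT assay, with a stated time of 96 h; a lower number here means that less compound is tolerated, a higher number that more compound is tolerated):
- Compound 1 (`Fc1ccc(F)c(/N=N/Nc2cccc(C(F)(F)F)c2)c1`) gives (> 100000 nM), a limit of the assay and not a number.
- Compound 2 (`CN(C)CCCN(/N=N/c1cc(F)ccc1F)c1ccccc1`) gives (25000 nM).
- Compound 3 (`CN(C)CCCN(/N=N/c1ccccc1)c1cccc(C(F)(F)F)c1`) gives (49000 nM).

Compound 3 and compound 2 lie within the usual scatter of each other, so neither is placed ahead of the other. For compound 1 only a limit is available (> 100000 nM).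

The next compound to be measured is compound 4 (`CN(C)CCCN(/N=N/c1cc(F)ccc1F)c1cccc(C(F)(F)F)c1`). It is compound 3 with 2,5-difluorophenyl in place of phenyl on a double-bonded nitrogen. For the measured compounds named here, no measured pair isolates this change, so any expectation rests on indirect reading. Compound 2 also carries the 2,5-difluorophenyl and gives (25000 nM) in (this assay), which is the closest guide available. Going by the values given here, with only this value to go on, a small move toward a lower number is expected, of a size that probably stays within the scatter: the estimated step is (a 1.6-fold lower number from compound 3 to compound 4 (0.21 log units; within the scatter)). For compound 4 the estimated value is (30000 nM), with an expected range from (12000 nM) to (70000 nM).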

Compound 4, half-maximal cytotoxic concentration: 54000 nM
Compound 4: the middle estimate sits 1.8-fold (0.26 log units) below what was measured; the range from low to high includes it.
By their numbers in this assay, from the lowest: compounds 2, 3 and 4 (each within the scatter of the next, the first and the last beyond it). At a limit, above all of these: compound 1.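

In this assay, 2,5-difluorophenyl in place of phenyl on a double-bonded nitrogen gives no separable difference when the trifluoromethyl group is present: a 1.1-fold higher number from compound 3 to compound 4 (0.04 log units; within the scatter). Trifluoromethyl in place of hydrogen on an aromatic carbon gives the only step here that is a plain number beyond the scatter, although it is modest and rests on this single pair, with 2,5-difluorophenyl as the partner group: a 2.2-fold higher number from compound 2 to compound 4 (0.33 log units; beyond the scatter). Adding 3-(dimethylamino)propyl in place of hydrogen on a nitrogen on an aromatic ring gives an at least 1.8-fold lower number from compound 1 to compound 4 (0.26 log units; that floor lies within the scatter), which is only a floor and not a measured size, since compound 1 stands at a limit of the assay: the limit of > 100000 nM in this assay, at which 1 of the 4 values shown sits.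

From the compounds shown here alone, it remains open whether the trifluoromethyl step holds with phenyl as the partner group, and whether either fluorine alone would behave as 2,5-difluorophenyl does. Also open, going by these compounds, is how this assay would respond to a chlorine or a methoxy group in place of trifluoromethyl, or to a longer chain or a morpholine in place of the dimethylamino end of the side chain.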